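This account rests on a few compounds, and the source may have more. Where it says the series, first, only, none or still open, it means among the compounds named here.

Measured compounds in this series:

compound 1 `O=C(N/N=C/c1cccc(F)c1)c1cnccn1` — 49%
compound 2 `CCOc1ccc(/C=N/NC(=O)c2cnccn2)cc1` — 100%

In an ADME assay on J774 cells (Mus musculus) for cytotoxicity, read by MTT assay, with a stated time of 48 h, tested at 50 ug/mL (a lower number here means a stronger effect, a higher number a weaker effect of the compound at the concentration tested), compound 1 gives 49%, and compound 2 gives 100%. Compound 1 stands at the lowest of the two numbers, the stronger effect; compound 2 sits well beyond the scatter above it. Within the data shown here, no pair of measured compounds differs in only one place, so no measured step exists to guide the change considered here.

Compound 3 `N#Cc1cccc(/C=N/NC(=O)c2cnccn2)c1` is not yet measured. It differs from compound 1 as follows: cyano in place of fluoro on an aromatic carbon — the change sits on an aromatic carbon of a six-membered aromatic ring of carbon only. Among the measured compounds shown here, with no measured step of this kind, a modest shift is expected in this assay, most likely toward a weaker effect, of about a number 13 percentage points higher from compound 1 to compound 3 (beyond the scatter).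

For compound 3 the expected value is 62%, with a range from 35% to 90%.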

Compound 3, a percentage reported as activity, at one concentration (the size of the read-out at that concentration, not a potency): 100%
For compound 3 the middle estimate is 38 percentage points below the measured one; measured number outside the range, above it.
By their numbers in this assay, from the lowest: compound 1; then compounds 2 and 3 (each within the scatter of the next).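

Among these compounds, on the six-membered aromatic ring of carbon only, at the place meta to a large group, cyano in place of fluoro gives the first measured single-place step in this assay: a number 51 percentage points higher from compound 1 to compound 3 (beyond the scatter) is a large step. This place therefore bears strongly on the read-out, since one exchange on an aromatic carbon moves the number well beyond the scatter while the rest of the core of compound 1 stays the same. No measurement at hand explains this step.

As far as these compounds go, whether the stronger effect of compound 1 is particular to fluoro, or is shared by chloro or methoxy at the same place, stays open. So does the outcome for an amine or a carboxylic acid there.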